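Permeability notes: oxan-4-yl replacing cyclohexyl in compound 4

The source may report more compounds than this note shows. Statements on the series, on what has been measured and on what is new or still open speak of the compounds shown alone.

Measured compounds:
compound 1 `O=C(O)c1ccc(NC(=O)[C@H](CC2CCCC2)n2cnc(S(=O)(=O)C3CCC3)c2)nc1` — 0.5 10^-6 cm/s
compound 2 `O=C(O)c1ccc(NC(=O)[C@H](CC2CCCCC2)n2cnc(S(=O)(=O)C3CC3)c2)nc1` — 0.5 10^-6 cm/s
compound 3 `O=C(O)c1ccc(NC(=O)[C@H](CC2CCCCC2)n2cnc(S(=O)(=O)C3CCC3)c2)nc1` — 0.3 10^-6 cm/s

In an ADME assay on MDCKII-LE cells (Canis lupus familiaris) for permeability (a higher number here means that the compound crosses the layer faster, a lower number that the compound crosses the layer more slowly), compound 3 gives 0.3 10^-6 cm/s and so sits at the low end of the three numbers, yet a 1.7-fold lower number from compound 1 to compound 3 (0.22 log units; within the scatter) and a 1.7-fold lower number from compound 2 to compound 3 (0.22 log units; within the scatter) both fall within the scatter, so the three compounds are not separated from one another on this read-out. Compound 4 `O=C(O)c1ccc(NC(=O)[C@H](CC2CCOCC2)n2cnc(S(=O)(=O)C3CCC3)c2)nc1` differs from compound 3 by oxan-4-yl in place of cyclohexyl on a saturated chain carbon, two bonds along the chain from an aromatic nitrogen and a carbonyl carbon. For the measured compounds named here, of the measured steps, only a 1.7-fold lower number from compound 1 to compound 3 (0.22 log units; within the scatter) touches the same place, and there it exchanged one carbocycle for another of a different size; no measured step trades a ring carbon for a ring oxygen, so the present change has no direct precedent. Both measured steps were small, and the three numbers cluster closely, which gives no basis to expect a movement beyond the scatter. The estimated step is no change at the digits printed from compound 3 to compound 4 (within the scatter) for compound 4. The number expected for compound 4 is 0.3 10^-6 cm/s, within a range from 0.1 10^-6 cm/s to 0.7 10^-6 cm/s.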

Compound 4, apparent permeability in the MDCKII-LE assay: 0.9 10^-6 cm/s
Compound 4: the middle estimate sits 3.0-fold (0.48 log units) below what was measured; the measured number lies above the stated range.
By their numbers in the MDCKII-LE assay, from the lowest: compounds 3, 1, 2 and 4 (each within the scatter of the next, the first and the last beyond it).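

For the compounds shown here, in the MDCKII-LE assay, a 3.0-fold higher number from compound 3 to compound 4 (0.48 log units; beyond the scatter) is the first step at this position to lie beyond the scatter, whereas the exchange of one carbocycle for another, a 1.7-fold lower number from compound 1 to compound 3 (0.22 log units; within the scatter), did not. The separation holds only against cyclohexyl, since a 1.8-fold higher number from compound 1 to compound 4 (0.26 log units; within the scatter) leaves oxan-4-yl unresolved from cyclopentyl on this read-out. In a physicochemical assay for lipophilicity, at pH 7.4 (a higher number here means a more lipophilic compound, a lower number a more polar compound), compound 3 gives 0.15 and compound 4 gives -1.55. In the physicochemical assay, the same exchange runs in the opposite direction, so at this place a higher permeability number came with a much lower lipophilicity number in this one pair: the measured distribution coefficient of compound 3, 0.15, and of compound 4, -1.55, a number 1.70 log units lower (beyond the scatter)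

A single pair cannot show whether the two read-outs move together across the series. Also open, from the compounds shown here alone, is how an oxolan-3-yl or a piperidine amine would read at this place, and whether oxan-4-yl gives a similar step with the cyclopropyl on the sulfonyl sulfur of compound 2.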